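One Aryl Exchange at the Ring Nitrogen: Expected Inhibition

The compounds below may be only part of what the source reports. "The series", "measured", "known", "first", "only" and "open" are said of these compounds alone.

Three compounds have been measured in a functional assay on A-431 cells (Homo sapiens), tested at 0.1 uM; a lower number here means less inhibition, a higher number more inhibition at the concentration tested (going by the name of the read-out):

compound 1, `Fc1ccc(CNc2ncccc2-c2n[nH]c(Nc3ccc4c(c3)OCCO4)n2)cc1F`: 32%
compound 2, `COc1ccc(CNc2ncccc2-c2n[nH]c(Nc3ccc4c(c3)OCCO4)n2)cc1`: 30%
compound 3, `COc1cc(OC)cc(Oc2ncccc2-c2n[nH]c(Nc3cccc(O)c3)n2)c1`: 86%

Compound 3 stands highest of the three, with compound 1 and compound 2 both well below it, beyond the scatter. Compound 4 `COc1cc(OC)cc(Oc2ncccc2-c2n[nH]c(Nc3ccc4c(c3)OCCO4)n2)c1` takes the step from compound 3: 2,3-dihydro-1,4-benzodioxin-6-yl in place of 3-hydroxyphenyl on a nitrogen on an aromatic ring. Among the measured compounds shown here, the only measured step, a number 2 percentage points lower from compound 1 to compound 2 (within the scatter), alters a different part of the molecule and does not bear directly on this exchange. Compounds 1 and 2 carry the entering group on the same nitrogen and both show weak inhibition, yet they also differ from compound 3 elsewhere, so the effect of this exchange alone is not shown. Compound 4 is therefore expected to drop by a number 24 percentage points lower from compound 3 to compound 4 (beyond the scatter), to an estimated 62%, between 30% and 88%.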

Compound 4, a percentage reported as inhibition, at one concentration (the size of the read-out at that concentration, not a potency): 89%
Beside the measured number, compound 4's estimate is 27 percentage points below it; measured number above the stated range.
By their numbers in this assay, from the lowest: compounds 2 and 1 (each within the scatter of the next); then compounds 3 and 4 (each within the scatter of the next).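

In this assay the exchange of 3-hydroxyphenyl for 2,3-dihydro-1,4-benzodioxin-6-yl on the nitrogen gives a number 3 percentage points higher from compound 3 to compound 4 (within the scatter) and so leaves inhibition in place with 3,5-dimethoxyphenoxy on the core. Among the compounds shown here, the weak inhibition of the earlier compounds therefore does not follow the benzodioxinyl group: the exchange of the benzylamino groups for 3,5-dimethoxyphenoxy gives a number 59 percentage points higher from compound 2 to compound 4 (beyond the scatter) and a number 57 percentage points higher from compound 1 to compound 4 (beyond the scatter) with that group held constant. Nothing available explains these numbers. Going by these compounds, whether 3-hydroxyphenyl would match the benzodioxinyl group alongside (4-methoxybenzyl)amino remains open, as does what an amine or a carboxylic acid on the phenyl ring would give.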